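This account rests on a few compounds, and the source may have more. Where it says the series, first, only, none or still open, it means among the compounds named here.

Measured so far in an ADME assay on MT4 cells (Homo sapiens) for cytotoxicity, read by MTT assay, with a stated time of 4 days; a higher number here means that more compound is tolerated, a lower number that less compound is tolerated:
compound 1 `Cc1cc(-c2ccc(C#N)cc2)cc(C)c1Nc1ccnc(Nc2ccc(C#N)cc2)n1` gives 2080 nM
compound 2 `Cc1cc(-c2ccccc2C(F)(F)F)cc(C)c1Nc1ccnc(Nc2ccc(C#N)cc2)n1` gives 4210 nM

Compound 2 stands highest of the two numbers. For the measured compounds named here, its nearest neighbour is compound 1, and the one step measured so far, a 2.0-fold higher number from compound 1 to compound 2 (0.31 log units; beyond the scatter), is the step that separates them; it is a modest step, though beyond the scatter.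

The next compound, compound 3 `Cc1cc(-c2ccccc2F)cc(C)c1Nc1ccnc(Nc2ccc(C#N)cc2)n1`, differs from compound 2 in one place: fluoro in place of trifluoromethyl on an aromatic carbon. Going by the values given here, no measured pair makes this same exchange. Among the compounds with values here, the only step in hand, a 2.0-fold higher number from compound 1 to compound 2 (0.31 log units; beyond the scatter), swaps the whole aryl group, 2-(trifluoromethyl)phenyl in place of 4-cyanophenyl, so it shows that this part of the molecule can move the read-out by a modest amount, but it says nothing about the direction of a smaller change within the same group. With nothing closer to go on, compound 3 is expected to remain near compound 2, and the step of a 1.2-fold lower number from compound 2 to compound 3 (0.08 log units; within the scatter) is estimated to stay within the scatter. Compound 3 is therefore expected to give about 3500 nM in this assay, with a range from 1700 nM to 7500 nM.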

Compound 3, half-maximal cytotoxic concentration: 2120 nM
For compound 3 the middle estimate is 1.7-fold (0.22 log units) above the measured one; the range from low to high includes it.
By their numbers in this assay, from the lowest: compounds 1, 3 and 2 (each within the scatter of the next, the first and the last beyond it).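

Exchanging trifluoromethyl for fluoro on this aromatic carbon, ortho to a large group, gives in this assay a 2.0-fold lower number from compound 2 to compound 3 (0.30 log units; within the scatter), so removing most of the heavy atoms of that group leaves a step that stays within the scatter, though only just. For the compounds shown here, the exchange of 4-cyanophenyl for 2-fluorophenyl gives a 1.0-fold higher number from compound 1 to compound 3 (0.01 log units; within the scatter), so these two aryl groups read alike here, and only the pair joined by a 2.0-fold higher number from compound 1 to compound 2 (0.31 log units; beyond the scatter) stands beyond the scatter, with 2-fluorophenyl lying within the scatter of both other aryl groups. No measurement at hand bears on why these numbers fall as they do.

On these data alone, with only fluoro and trifluoromethyl at this place, it remains open whether the read-out follows the size of the group at all, and an unsubstituted phenyl would give the reference that both lack. As far as these compounds go, whether a methoxy, an amine or a carboxylic acid on the same aromatic carbon would stay within this small spread of numbers also remains open, as does whether the cyano group of 4-cyanophenyl or its place on the ring sets the number of compound 1.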